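Urea Amine Swap on a Quinolinyl Oxadiazole Piperidine

A few compounds are considered here, and "the series" means these few. Any claim that something is new, unique, unknown or untested is made for them only; others in the source may bear on it.

In a functional assay on Shh Light II cells (Mus musculus) for inhibition, read by a luciferase reporter (on this read-out higher numbers stand for weaker inhibition and lower numbers for stronger inhibition), compound 2 `O=C(N1CCC(c2nc(-c3ccc4ccccc4n3)no2)CC1)N1CCCc2ccccc21` gives 2300 nM, the highest of the two numbers measured. Compound 1 `CC(C)c1ccccc1NC(=O)N1CCC(c2nc(-c3ccc4ccccc4n3)no2)CC1` gives 480 nM in this assay. Compound 3 `Cc1noc(C)c1NC(=O)N1CCC(c2nc(-c3ccc4ccccc4n3)no2)CC1` differs from compound 2 in one place: (3,5-dimethyl-1,2-oxazol-4-yl)amino in place of 1,2,3,4-tetrahydroquinolin-1-yl on a carbonyl carbon. Within the data shown here, the only step that bears on this change is a 4.8-fold higher number from compound 1 to compound 2 (0.68 log units; beyond the scatter), a modest rise when an arylamino urea became the ring-fused amine; compound 3 returns to an arylamino urea, so a modest fall in this assay is expected. Compound 3 is therefore estimated at 700 nM, with a range of 250 nM to 2500 nM, an expected step of a 3.3-fold lower number from compound 2 to compound 3 (0.52 log units; beyond the scatter).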

Compound 3, half-maximal inhibitory concentration: 3000 nM
Estimate against measurement, compound 3: 4.3-fold (0.63 log units) below; the measured number lies above the stated range.
By their numbers in this assay, from the lowest: compound 1; then compounds 2 and 3 (each within the scatter of the next).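

In this assay a return to an arylamino urea does not by itself bring back the number of compound 1: the swap gives a 1.3-fold higher number from compound 2 to compound 3 (0.12 log units; within the scatter) and so leaves the two groups unresolved at this carbonyl carbon. The difference among the arylamino ureas lies in the aryl group on the amide-type nitrogen, with a 6.3-fold higher number from compound 1 to compound 3 (0.80 log units; beyond the scatter) as the 2-isopropylphenyl gives way to the 3,5-dimethyl-1,2-oxazol-4-yl. No evidence on hand accounts for this. As far as these compounds go, whether a plain phenyl or a 2-methoxyphenyl on that nitrogen would stand nearer compound 1 or compound 3 stays open.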